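Removing Two Chlorines from Compound 1: an Expectation

The compounds below may be only part of what the source reports. "The series", "measured", "known", "first", "only" and "open" are said of these compounds alone.

Measured in a functional assay on the whole organism for inhibition, with Mythimna separata as the target, with a stated time of 5 days; on this read-out lower numbers stand for an effect already at smaller amounts and higher numbers for an effect only at larger amounts of compound:
Compound 1, `CC(C)(C)n1ncc(OCc2nnc(-c3ccc(Cl)cc3Cl)s2)c(Cl)c1=O`, gives 62.2 ug/mL.
Compound 2, `CC(C)(C)n1ncc(OCc2nnc(-c3cc(F)c(Cl)c([N+](=O)[O-])c3Cl)o2)c(Cl)c1=O`, reaches only a limit of the assay, > 300 ug/mL.
Compound 3, `CCn1ncc(OCc2nnc(-c3ccc(F)cc3)o2)c(Cl)c1=O`, likewise reaches only a limit of the assay, > 300 ug/mL.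

Compound 1 stands as the only one of the three with a number in this assay; the other two sit at the limit of > 300 ug/mL in this assay, at which 2 of the 3 values shown sit. Within the data shown here, no two measured compounds differ in just one place, so no single step has been measured. Compound 2 and compound 3 differ from compound 1 in more than one place; they do not show what the change below does on its own.

The unmeasured compound 4, `CC(C)(C)n1ncc(OCc2nnc(-c3ccccc3)s2)c(Cl)c1=O`, differs from compound 1 by phenyl in place of 2,4-dichlorophenyl on an aromatic carbon. Given that compound 2 and compound 3 both sit at the limit of > 300 ug/mL in this assay, at which 2 of the 3 values shown sit, the expectation for compound 4 is a step toward a weaker effect, beyond the scatter, estimated as a 2.6-fold higher number from compound 1 to compound 4 (0.41 log units; beyond the scatter). Compound 4 is accordingly expected to give about 160 ug/mL, in a range from 55 ug/mL to 300 ug/mL, with a real chance that it too is reported only at a limit.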

Compound 4, half-maximal effective concentration: 200 ug/mL
Compound 4: the middle estimate sits 1.3-fold (0.10 log units) below what was measured; the range from low to high includes it.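

In this assay, among these compounds, this is the first single change whose size can be read: replacing 2,4-dichlorophenyl with plain phenyl on the aromatic carbon of the shared core gives a 3.2-fold higher number from compound 1 to compound 4 (0.51 log units; beyond the scatter). The step is modest but lies beyond the scatter, so at this position the version with the two chlorine atoms has the stronger effect, and losing both costs some of that effect without abolishing it. Compound 4 still has a measured number, so this change alone does not take the compound to the ceiling of the assay, which is a limit and not a number: the limit of > 300 ug/mL in this assay, at which 2 of the 4 values shown sit.

Going by these compounds, both chlorine atoms leave in one step, so the share of each in the difference remains unknown, and a ring carrying only one of them would be needed to separate the two. Also open, on these data alone, is how a different group on the phenyl ring, such as a methoxy group, an amine or a trifluoromethyl group, would compare with either chlorine or plain hydrogen at this position.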